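The source may hold more compounds than are shown below. What is called first, only, known or untested is meant among the compounds shown, and "the series" means these compounds.

Measured so far in a functional assay on K562 cells (Homo sapiens) for cytotoxicity, in the presence of a further agent that is not named here; on this read-out higher numbers stand for weaker inhibition and lower numbers for stronger inhibition:
Compound 1 `Clc1ccc(-c2cc(-c3ccsc3)nc(-c3ccccc3Cl)c2)o1` gives 17200 nM.
Compound 2 `Clc1ccc(-c2cc(-c3cccs3)nc(-c3ccccc3Cl)c2)o1` gives 17200 nM.
Compound 3 `Clc1ccc(-c2cc(-c3ccoc3)cc(-c3cccs3)n2)cc1` gives 21100 nM.

Compound 4 `Clc1ccc(-c2cc(-c3ccoc3)cc(-c3ccsc3)n2)cc1` has not yet been measured. The change that turns compound 3 into compound 4 is thiophen-3-yl in place of thiophen-2-yl on an aromatic carbon. The same change has been made once before, from compound 2 to compound 1: thiophen-3-yl in place of thiophen-2-yl on an aromatic carbon. That step came out as no change at the digits printed from compound 2 to compound 1 (within the scatter). How the core of compound 3 differs from the core of compound 2 is not broken down here. The surroundings of the changed carbon are not identical in the two cases: in compound 2 it is meta to a 2-chlorophenyl group and meta to a 5-chlorofuran-2-yl group, whereas in compound 3 it is meta to a 4-chlorophenyl group and meta to a furan-3-yl group, so the two changes are of the same kind rather than the same. The three measured values all lie within the scatter of one another. Within the data shown here, the step from compound 3 to compound 4 is expected to be a 1.0-fold lower number from compound 3 to compound 4 (0.00 log units; within the scatter), resting on no change at the digits printed from compound 2 to compound 1 (within the scatter) as the only earlier example of this swap. Compound 4 is therefore estimated at 21000 nM in this assay, with a likely range from 10000 nM to 45000 nM.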

Compound 4, half-maximal inhibitory concentration: 730 nM
Estimate against measurement, compound 4: 29-fold (1.46 log units) above, outside the stated range (below it).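

On the core of compound 3, in this assay, putting thiophen-3-yl in place of thiophen-2-yl gives a 29-fold lower number from compound 3 to compound 4 (1.46 log units; beyond the scatter). The same swap therefore had clearly different outcomes on the two cores: the same change on two cores in this assay, no change at the digits printed (within the scatter) from compound 2 to compound 1 and a 29-fold lower number (1.46 log units; beyond the scatter) from compound 3 to compound 4, 29-fold (1.46 log units) apart, beyond the scatter of two such steps This shows that the result of this swap on one core is no safe guide to its result on another in this series, but it does not show what lies behind the gap, as compound 2 and compound 3 differ in more than one place and two pairs cannot single out which difference matters.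

As far as these compounds go, it remains open whether the drop in the number seen with compound 4 would persist if only its 4-chlorophenyl group were replaced by a 2-chlorophenyl group, or only its furan-3-yl group by a 5-chlorofuran-2-yl group. Also open, from the compounds shown here alone, is how the compound 4 core would respond to a different kind of group, such as an amine or a carboxylic acid, in place of either thiophene or furan ring.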